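A few compounds are considered here, and "the series" means these few. Any claim that something is new, unique, unknown or untested is made for them only; others in the source may bear on it.

In a functional assay on NALM-6 cells (Homo sapiens) (on this read-out lower numbers stand for stronger inhibition and higher numbers for weaker inhibition), compound 1 `CCCCCSC[C@H](NC(C)=O)C(=O)CCl` gives 5800 nM, compound 2 `CCCCCCCSC[C@H](NC(C)=O)C(=O)CCl` gives 4800 nM and compound 3 `CCCCCCCCSC[C@H](NC(C)=O)C(=O)CCl` gives 5600 nM; compound 3 thus sits in the middle of three numbers that all lie within the usual scatter of one another. Compound 4 `CCCCCCCCCCSC[C@H](NC(C)=O)C(=O)CCl` differs from compound 3 by ethyl in place of hydrogen on a saturated chain carbon, eight bonds along the chain from a sulfur. The chain-lengthening steps measured so far, namely a 1.2-fold lower number from compound 1 to compound 2 (0.08 log units; within the scatter), a 1.0-fold lower number from compound 1 to compound 3 (0.02 log units; within the scatter) and a 1.2-fold higher number from compound 2 to compound 3 (0.07 log units; within the scatter), all stayed within the scatter, so a further lengthening of the same chain is expected to produce no step beyond the scatter in this assay either. Compound 4 is therefore estimated at 5500 nM, with a range from 2500 nM to 12000 nM, which corresponds to an expected step of a 1.0-fold lower number from compound 3 to compound 4 (0.01 log units; within the scatter).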

Compound 4, half-maximal inhibitory concentration: 4700 nM
Compound 4: the middle estimate sits 1.2-fold (0.07 log units) above what was measured; measured number inside the range.
By their numbers in this assay, from the lowest: compounds 4, 2, 3 and 1 (each within the scatter of the next).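

In this assay the longest chain shown stays within the scatter of all three shorter ones: ethyl on a saturated chain carbon, eight bonds along the chain from a sulfur, gives (a 1.2-fold lower number from compound 3 to compound 4 (0.08 log units; within the scatter)), propyl at seven bonds gives (a 1.0-fold lower number from compound 2 to compound 4 (0.01 log units; within the scatter)) and pentyl at five bonds gives (a 1.2-fold lower number from compound 1 to compound 4 (0.09 log units; within the scatter)). Ethyl now gives matching steps at two places on the chain: (the same change on two cores in this assay, a 1.2-fold lower number (0.08 log units; within the scatter) from compound 1 to compound 2 and a 1.2-fold lower number (0.08 log units; within the scatter) from compound 3 to compound 4, 1.0-fold (0.01 log units) apart, within the scatter of two such steps). Propyl does the same: (the same change on two cores in this assay, a 1.0-fold lower number (0.02 log units; within the scatter) from compound 1 to compound 3 and a 1.0-fold lower number (0.01 log units; within the scatter) from compound 2 to compound 4, 1.0-fold (0.01 log units) apart, within the scatter of two such steps). Going by these compounds, whether a still longer chain, or a chain ending in an amine or a carboxylic acid, would give a step beyond the scatter remains open.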